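The source may report more compounds than this note shows. Statements on the series, on what has been measured and on what is new or still open speak of the compounds shown alone.

Measured compounds:
- compound 1, `CC(C)(C)OC(=O)N1CCC[C@@H]1C(=O)N1CCC(NS(=O)(=O)c2cc(S(=O)(=O)c3ccccc3)ccc2C(F)(F)F)CC1`: 210 nM
- compound 2, `CC(=O)N1CCC[C@H]1C(=O)N1CCC(NS(=O)(=O)c2cc(S(=O)(=O)c3ccccc3)ccc2C(F)(F)F)CC1`: 250 nM
- compound 3, `CC(C)C(=O)N1CCC[C@H]1C(=O)N1CCC(NS(=O)(=O)c2cc(S(=O)(=O)c3ccccc3)ccc2C(F)(F)F)CC1`: 90 nM

All three values come from a functional assay on U2OS cells for antagonist activity at proto-oncogene Wnt-3 (Homo sapiens), read by a luciferase reporter, with a stated time of 18 h; a higher number here means that more compound is needed for the effect, a lower number that less compound is needed. Compound 3 gives the lowest number of the three: against compound 1 the step is a 2.3-fold lower number from compound 1 to compound 3 (0.37 log units; beyond the scatter), against compound 2 it is a 2.8-fold lower number from compound 2 to compound 3 (0.44 log units; beyond the scatter), both beyond the scatter, so compound 3 stands apart from the other two. Between compound 1 and compound 2 the step is a 1.2-fold higher number from compound 1 to compound 2 (0.08 log units; within the scatter), within the scatter.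

Compound 4, `CC(C)(C)CC(=O)N1CCC[C@H]1C(=O)N1CCC(NS(=O)(=O)c2cc(S(=O)(=O)c3ccccc3)ccc2C(F)(F)F)CC1`, differs from compound 3 by neopentyl in place of isopropyl on a carbonyl carbon. Among the compounds with values here, the steps that bear on this are those that change the group on the same carbonyl carbon: the step of a 2.8-fold lower number from compound 2 to compound 3 (0.44 log units; beyond the scatter) shows that going from methyl to isopropyl lowered the number modestly, and a 2.3-fold lower number from compound 1 to compound 3 (0.37 log units; beyond the scatter) shows a similar gain against the tert-butoxycarbonyl group. Nothing here shows how a group larger than isopropyl behaves, so the expected step of a 1.1-fold lower number from compound 3 to compound 4 (0.02 log units; within the scatter) in this assay is taken as none beyond the scatter, with an even chance either way. Compound 4 is therefore estimated at 85 nM, with a range of 30 nM to 250 nM.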

Compound 4, half-maximal effective concentration: 120 nM
The estimate for compound 4 lay 1.4-fold (0.15 log units) below the measured number; the measured number falls inside the stated range.
By their numbers in this assay, from the lowest: compounds 3, 4, 1 and 2 (each within the scatter of the next, the first and the last beyond it).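

In this assay the change from isopropyl to neopentyl, 5 heavy atoms in place of 3, gives a 1.3-fold higher number from compound 3 to compound 4 (0.12 log units; within the scatter) and so leaves the two compounds indistinguishable. The drop from the methyl group of compound 2 is therefore not confined to isopropyl, since neopentyl also gives a 2.1-fold lower number from compound 2 to compound 4 (0.32 log units; beyond the scatter) as a modest step beyond the scatter. Against the tert-butoxycarbonyl group, the result is a 1.8-fold lower number from compound 1 to compound 4 (0.24 log units; within the scatter) and does not separate neopentyl from that group.

No measurement here offers an explanation for these steps.

Still open, going by these compounds, is how a ring on this carbonyl carbon, such as phenyl or cyclohexyl, would behave, and whether an amine, a carboxylic acid or a longer chain would keep the number in this range.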